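The source may report more compounds than this note shows. Statements on the series, on what has been measured and on what is new or still open speak of the compounds shown alone.

Compound 1 `Cc1nc(N)sc1CCCN/C(N)=N/C(=O)N[C@H](C)c1ccccc1` and compound 2 `Cc1nc(N)sc1CCCN/C(N)=N/C(=O)NCc1ccccc1` share one core and differ only by a number 0.010 lower from compound 1 to compound 2 (within the scatter). In a functional assay on HEK293T cells for agonist activity at histamine H2 receptor (Homo sapiens), read by beta-arrestin recruitment (on this read-out higher numbers stand for larger maximal responses and lower numbers for smaller maximal responses), compound 1 gives 0.34, and compound 2 gives 0.33, a number that sits within the usual scatter of compound 1's. Compound 3 `Cc1nc(N)sc1CCCN/C(N)=N/C(=O)NC1CCCCC1` differs from compound 2 by cyclohexyl in place of benzyl on an amide-type nitrogen. For the measured compounds named here, no measured step exchanges one ring for another on that nitrogen, so nothing measured bears directly on this change; the one measured step stayed within the scatter. The expected step here, no change at the digits printed from compound 2 to compound 3 (within the scatter) in this assay, is likewise none beyond the scatter. Compound 3 is therefore estimated at 0.33, between 0.2 and 0.48.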

Compound 3, intrinsic activity: the largest response reached, as a fraction of the reference agonist's: 0.43
For compound 3 the middle estimate is 0.10 below the measured one; measured number inside the range.
By their numbers in this assay, from the lowest: compounds 2, 1 and 3 (each within the scatter of the next).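

In this assay, cyclohexyl in place of benzyl on the amide-type nitrogen gives a number 0.10 higher from compound 2 to compound 3 (within the scatter), and cyclohexyl in place of 1-phenylethyl gives a number 0.090 higher from compound 1 to compound 3 (within the scatter). The earlier pair both carried an aromatic ring there, so only now is it seen that a non-aromatic ring of carbon only also keeps the response within the scatter of those two. No evidence shown here gives a reason for this result. Still open, going by these compounds, is whether a smaller ring such as cyclopentyl, or a cyclohexyl ring bearing an amine or a carboxylic acid, would keep the response in this range.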